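A few compounds are considered here, and "the series" means these few. Any claim that something is new, unique, unknown or untested is made for them only; others in the source may bear on it.

Measured compounds:
compound 1, `ClCc1ccccc1Cn1cnc2c(Cl)nc(Cl)nc21`, in a functional assay on SNB-19 cells (Homo sapiens) for cytotoxicity, read by sulforhodamine B assay, with a stated time of 48 h; on this read-out higher numbers stand for weaker inhibition of growth and lower numbers for stronger inhibition of growth: "not determined" (no result reported)
compound 2, `ClCc1ccccc1Cn1cnc2c(Cl)ncnc21`, in this assay: > 100000 nM
compound 3, `ClCc1cccc(Cn2cnc3ncnc(Cl)c32)c1`, in this assay: "not determined" (no result reported)

Compound 3 stands without a number in this assay; its entry reads "not determined" (no result reported). Of the three entries shown, one further value is a limit and one further entry carries no number. Compound 2 sits at a limit of the assay, > 100000 nM, which is not a measured number. Compound 1 likewise has no result, "not determined" (no result reported). Compound 4, `ClCc1cccc(Cn2cnc3nc(Cl)nc(Cl)c32)c1`, differs from compound 3 by chloro in place of hydrogen on an aromatic carbon, in words chloro in place of hydrogen on an aromatic carbon. Going by the values given here, no step between two measured compounds exists here, so there is nothing to set the size or direction of this change against, and any expectation for this assay can only be that the step stays within the usual scatter or is simply unknown. The sole reference point is the limit of > 100000 nM in this assay, at which 1 of the 3 values shown sits, the position occupied by compound 2. On that thin basis, compound 4 is estimated at 80000 nM in this assay, with an expected range from 20000 nM to 300000 nM, and a strong chance that only a limit is reported.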

Compound 4, concentration for total growth inhibition: 2690 nM
For compound 4 the middle estimate is 30-fold (1.47 log units) above the measured one; the measured number lies below the stated range.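

In this assay, going by these compounds alone, compound 4 gives 2690 nM while compound 3 has no number, so no step from compound 3 to compound 4 can be read. The compounds shown leave open what chloro in place of hydrogen on an aromatic carbon changes in this read-out. Nothing shown bears on the reason for the result of compound 4.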